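This account rests on a few compounds, and the source may have more. Where it says the series, first, only, none or still open, it means among the compounds named here.

Measured compounds in a functional assay on the whole organism (strain Sprague-Dawley) for inhibition, with Rattus norvegicus as the target; a higher number here means that more compound is needed for the effect, a lower number that less compound is needed: compound 1 `CCc1cccc2c(=O)c(-c3nn[nH]n3)c[nH]c12`, compound 2 `FC(F)(F)c1cccc2cc(-c3nn[nH]n3)cnc12`, compound 3 `O=c1c(-c2nn[nH]n2)c[nH]c2c(C(F)(F)F)cccc12`. In this assay compound 2 gives 25 mg/kg. Compound 1 reaches only a limit of the assay, > 25 mg/kg. Compound 3 likewise shows only a limit, > 25 mg/kg. So compound 2 carries the only number in the set; the other two values are limits (the limit of > 25 mg/kg in this assay, at which 2 of the 3 values shown sit).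

The change ethyl in place of trifluoromethyl on an aromatic carbon gives the step that the two limits leave unreadable from compound 3 to compound 1. The same change is now to be made on the core of compound 2, yielding compound 4 `CCc1cccc2cc(-c3nn[nH]n3)cnc12`, not yet measured: ethyl in place of trifluoromethyl on an aromatic carbon. The difference between the core of compound 2 and the core of compound 3 is not broken down here.

The measured step gives no readable size, so the expectation for compound 4 rests mainly on the value of compound 2, 25 mg/kg, with wide uncertainty. The step from compound 2 to compound 4 is estimated as no change at the digits printed from compound 2 to compound 4 (within the scatter), so compound 4 is expected to give about 25 mg/kg, from 10 mg/kg to 60 mg/kg in this assay.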

Compound 4, minimum effective dose: 5 mg/kg
Compound 4: middle estimate off by 5.0-fold (0.70 log units), on the high side; measured number below the stated range.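

In this assay, ethyl in place of trifluoromethyl on an aromatic carbon gives a 5.0-fold lower number from compound 2 to compound 4 (0.70 log units; beyond the scatter), so on this core the change lowers the dose needed, by a modest step beyond the scatter. On the other core the same change cannot be read, since compound 3 and compound 1 both stand at a limit and not at a number: the limit of > 25 mg/kg in this assay, at which 2 of the 4 values shown sit. The series therefore gives one readable size for this change, on one core only, and neither confirms nor contradicts its carrying over from one core to the other.

Going by these compounds, only ethyl and trifluoromethyl appear at this position, so it remains open how a longer chain such as propyl, or a methoxy group or an amine, would compare with ethyl on the core of compound 4. On these data alone, it also remains open whether any such group on the core of compound 1 would give a number in this assay rather than a limit.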